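Aryl swap on the pyrrolidine-linked core: notes

The compounds below may be only part of what the source reports. "The series", "measured", "known", "first", "only" and "open" are said of these compounds alone.

Compound 1 `COc1cc2c(Oc3ccc(NC(=O)c4cc(-c5ccccc5F)ccn4)cc3F)ccnc2cc1OCCCN1CCN(C)CC1` is the reference point here. In a functional assay on NCI-H460 cells (Homo sapiens) for cytotoxicity, read by MTT assay, with a stated time of 72 h (a higher number here means a weaker inhibitor, a lower number a stronger inhibitor), compound 1 gives 140 nM. Compound 2 `COc1cc2c(Oc3ccc(NC(=O)c4cc(-c5ccc(C(F)(F)F)cc5)ccn4)cc3F)ccnc2cc1OCCCN1CCN(C)CC1` differs from it in one place, (4-(trifluoromethyl)phenyl in place of 2-fluorophenyl on an aromatic carbon), and in this assay compound 2 gives 160 nM, a step of a 1.1-fold higher number from compound 1 to compound 2 (0.06 log units; within the scatter). Compound 3 `COc1cc2c(Oc3ccc(NC(=O)c4cc(-c5ccccc5F)ccn4)cc3F)ccnc2cc1OCCCN1CCCC1` keeps the aryl group of compound 1 but carries a different amine on the chain, (pyrrolidin-1-yl in place of 4-methylpiperazin-1-yl on a saturated chain carbon, three bonds along the chain from an oxygen on an aromatic ring); in this assay compound 3 gives 140 nM, so no change at the digits printed from compound 1 to compound 3 (within the scatter). The three measured numbers sit within the usual scatter of one another, and no order among them can be read from these digits.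

Compound 4 `COc1cc2c(Oc3ccc(NC(=O)c4cc(-c5ccc(C(F)(F)F)cc5)ccn4)cc3F)ccnc2cc1OCCCN1CCCC1` has not yet been measured. It stands to compound 3 as compound 2 stands to compound 1: 4-(trifluoromethyl)phenyl in place of 2-fluorophenyl on an aromatic carbon. The cores differ as described for compound 3 against compound 1, and the place of the aryl change is described in the same words for both pairs, so this is the same change made on the pyrrolidine-linked core. For this assay the expected step of a 1.1-fold higher number from compound 3 to compound 4 (0.06 log units; within the scatter) from compound 3 to compound 4 is set beside the measured 1.1-fold higher number from compound 1 to compound 2 (0.06 log units; within the scatter), because a 1.1-fold higher number from compound 1 to compound 2 (0.06 log units; within the scatter) is the same change made on the core of compound 1 and stays within the scatter. Compound 4 is therefore estimated at 160 nM in this assay, with an expected range from 90 nM to 300 nM.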

Compound 4, half-maximal inhibitory concentration: 250 nM
The estimate for compound 4 lay 1.6-fold (0.19 log units) below the measured number; the measured number falls inside the stated range.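

In this assay the aryl change on the pyrrolidine-linked core gives a 1.8-fold higher number from compound 3 to compound 4 (0.25 log units; within the scatter), and the two aryl-matched compounds read across the amine change give a 1.6-fold higher number from compound 2 to compound 4 (0.19 log units; within the scatter), so the aryl change reads alike on both cores: the same change on two cores in this assay, a 1.1-fold higher number (0.06 log units; within the scatter) from compound 1 to compound 2 and a 1.8-fold higher number (0.25 log units; within the scatter) from compound 3 to compound 4, 1.6-fold (0.19 log units) apart, within the scatter of two such steps

The amine change likewise reads alike with either aryl group: the same change on two cores in this assay, no change at the digits printed (within the scatter) from compound 1 to compound 3 and a 1.6-fold higher number (0.19 log units; within the scatter) from compound 2 to compound 4, 1.6-fold (0.19 log units) apart, within the scatter of two such steps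

This shows that, across these four compounds, each change carries from one core to the other without a difference that can be told from the scatter, but since every step here also lies within the scatter, it does not show that a change with a clear effect would carry over, nor does it set any order among the four compounds.

Open, as far as these compounds go, is whether a morpholin-4-yl or dimethylamino group on the chain, a longer chain, or a phenyl ring bearing a nitrile or a carboxylic acid in place of these aryl groups would give a step beyond the scatter. Also open, from the compounds shown here alone, is whether such a step, once seen on one core, would appear at the same size on the other.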